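Replacing a Methoxyphenyl with a Thiophene on a Shared Core

The source may hold more compounds than are shown below. What is called first, only, known or untested is meant among the compounds shown, and "the series" means these compounds.

Three measured compounds share one core and differ only in the aromatic group attached to it. Compound 1 `c1ccc2c(-c3cn4ccnc4c(-c4ccc5ncn(C6CCCCC6)c5c4)n3)cccc2c1` carries naphthalen-1-yl, and in a functional assay on UACC-62 cells (Homo sapiens) for inhibition, read by sulforhodamine B assay, with a stated time of 48 h, tested at 10 uM (on this read-out higher numbers stand for more inhibition at the one concentration tested (going by the name of the read-out) and lower numbers for less inhibition), compound 1 gives 16.7%. Compound 2 `CC(=O)c1ccc(-c2cn3ccnc3c(-c3ccc4ncn(C5CCCCC5)c4c3)n2)cc1` gives 18.5%, a change of a number 1.8 percentage points higher from compound 1 to compound 2 (within the scatter). Compound 3 `COc1ccccc1-c1cn2ccnc2c(-c2ccc3ncn(C4CCCCC4)c3c2)n1` gives 25.1%; this is the highest of the three numbers, yet the other two sit within the scatter of it, with a number 8.4 percentage points higher from compound 1 to compound 3 (within the scatter) and a number 6.6 percentage points higher from compound 2 to compound 3 (within the scatter), so the three cannot be told apart on these figures.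

Compound 4 `c1csc(-c2cn3ccnc3c(-c3ccc4ncn(C5CCCCC5)c4c3)n2)c1` is not yet measured. It differs from compound 3 by thiophen-2-yl in place of 2-methoxyphenyl on an aromatic carbon. Among the measured compounds shown here, no measured step involves thiophen-2-yl, so the only steps that bear on it are the three exchanges of the aromatic group already seen, each of them within the scatter. On that basis the step of a number 6.1 percentage points lower from compound 3 to compound 4 (within the scatter) is expected to be small, with no direction beyond the scatter. Compound 4 is therefore estimated to give 19%, in a range from 6% to 32%.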

Compound 4, a percentage reported as inhibition, at one concentration (the size of the read-out at that concentration, not a potency): 24.8%
Beside the measured number, compound 4's estimate is 5.8 percentage points below it; the measured number falls inside the stated range.
By their numbers in this assay, from the lowest: compounds 1, 2, 4 and 3 (each within the scatter of the next).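

In this assay, the position next to the ring nitrogen now holds a five-membered aromatic ring with one sulfur, and exchanging 2-methoxyphenyl (8 heavy atoms) for thiophen-2-yl (5 heavy atoms) gives a number 0.3 percentage points lower from compound 3 to compound 4 (within the scatter), so removing the methoxy group and changing the ring size together leave no readable mark. The comparisons with the other two groups read the same way, with a number 6.3 percentage points higher from compound 2 to compound 4 (within the scatter) and a number 8.1 percentage points higher from compound 1 to compound 4 (within the scatter), which places thiophen-2-yl level with all three earlier groups on these figures. The range of aromatic groups that cannot be told apart at this position therefore now extends from a fused naphthalen-1-yl to a five-membered ring carrying a hetero atom, and nothing measured here accounts for this sameness.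

As far as these compounds go, all four groups are aromatic rings, so it remains open whether an amine, a carboxylic acid or a longer alkyl chain at this position would move the number beyond the scatter. From the compounds shown here alone, the cyclohexyl group is common to all four compounds, so the effect of changing it also remains open.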